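This account rests on a few compounds, and the source may have more. Where it says the series, first, only, none or still open, it means among the compounds named here.

In a functional assay on MV4-11 cells (Homo sapiens) for antiproliferative activity, read by CCK-8 assay, with a stated time of 72 h (a higher number here means a weaker inhibitor, a lower number a stronger inhibitor), compound 1 `Cc1cc(F)cc(C)c1Oc1ccc(C(C)(C)O)cc1-c1cn(C)c(=O)c2[nH]c(C(=O)NCc3ccc(C(=O)Nc4ccccc4N)cc3)cc12` gives 240 nM, compound 2 `COc1cccc(-c2cn(C)c(=O)c3[nH]c(C(=O)NCc4ccc(C(=O)Nc5ccccc5N)cc4)cc23)c1` gives 250 nM and compound 3 `COc1ccc(C(C)(C)O)cc1-c1cn(C)c(=O)c2[nH]c(C(=O)NCc3ccc(C(=O)Nc4ccccc4N)cc3)cc12` gives 420 nM. Compound 3 thus stands within the scatter of both others, as a 1.8-fold higher number from compound 1 to compound 3 (0.24 log units; within the scatter) and a 1.7-fold higher number from compound 2 to compound 3 (0.23 log units; within the scatter) show. Compound 4 `COc1ccccc1-c1cn(C)c(=O)c2[nH]c(C(=O)NCc3ccc(C(=O)Nc4ccccc4N)cc3)cc12` differs from compound 3 by one change, (hydrogen in place of 1-hydroxy-1-methylethyl on an aromatic carbon), which turns 5-(1-hydroxy-1-methylethyl)-2-methoxyphenyl into 2-methoxyphenyl. The step to compound 3 from compound 2 bears most directly, since it alters this same aryl group, and the step from compound 1 changes only the group on the oxygen. Neither left the scatter, so no step beyond the scatter is expected in this assay. The expected step is a 1.3-fold lower number from compound 3 to compound 4 (0.12 log units; within the scatter). For compound 4 the estimate is 320 nM, with an expected range of 140 nM to 720 nM.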

Compound 4, half-maximal inhibitory concentration: 200 nM
Beside the measured number, compound 4's estimate is 1.6-fold (0.20 log units) above it; low and high end bracket the measured number.
By their numbers in this assay, from the lowest: compounds 4, 1, 2 and 3 (each within the scatter of the next, the first and the last beyond it).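

In this assay, among the compounds shown here, the loss of the 1-hydroxy-1-methylethyl group gives the first step here to lie beyond the scatter, though a modest one, with a 2.1-fold lower number from compound 3 to compound 4 (0.32 log units; beyond the scatter) on removing it. Replacing 3-methoxyphenyl with 2-methoxyphenyl stays within the scatter, with a 1.3-fold lower number from compound 2 to compound 4 (0.10 log units; within the scatter) for that change. Nothing measured here accounts for the step at this position.

Open, as far as these compounds go, is how a smaller or differently built group at this carbon, such as an amine, a carboxylic acid or a hydroxymethyl, would compare. Also open, from the compounds shown here alone, is whether hydrogen here gives a similar step when the methoxy group is replaced by the 4-fluoro-2,6-dimethylphenyl ether of compound 1.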